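Working notes: furan-2-yl replaced by 3-fluorophenyl

The compounds below may be only part of what the source reports. "The series", "measured", "known", "first", "only" and "open" are said of these compounds alone.

Measured so far:
compound 1 `O=C(O)Cc1sc(C(c2ccc(F)cc2)c2ccc(F)cc2)nc1-c1ccnc(N2CCC2)c1`: 80%
compound 2 `O=C(O)Cc1sc(C(c2ccc(F)cc2)c2ccc(F)cc2)nc1-c1ccco1`: 80%

In an in vitro functional assay on HEK285-7 cells for antagonist activity at prostaglandin D2 receptor 2 (Homo sapiens), read by BRET and beta-arrestin recruitment (on this read-out lower numbers stand for smaller maximal responses and higher numbers for larger maximal responses), compound 1 gives 80%, and compound 2 gives 80%. Within the data shown here, the one step measured, no change at the digits printed from compound 1 to compound 2 (within the scatter), exchanges the aryl group on the shared core without moving the read-out beyond the scatter, so compound 2 stands level with compound 1 and has no other neighbour to compare against.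

Compound 3 `O=C(O)Cc1sc(C(c2ccc(F)cc2)c2ccc(F)cc2)nc1-c1cccc(F)c1` is not yet measured. Its change from compound 2 is 3-fluorophenyl in place of furan-2-yl on an aromatic carbon. Among the measured compounds shown here, the only step that bears on it is no change at the digits printed from compound 1 to compound 2 (within the scatter), which touched the same place on the core and showed no change; nothing measured here separates one aryl group from another at that position. The expected step is therefore no change at the digits printed from compound 2 to compound 3 (within the scatter), no change beyond the scatter. Compound 3 is estimated at 80%, within 65% to 95%.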

Compound 3, largest response reached (reported as efficacy), in percent of the reference or control that the assay uses: 80%
Estimate against measurement, compound 3: no gap at the digits printed, within the range that was stated.
By their numbers in this assay, from the lowest: compounds 1, 2 and 3 (each within the scatter of the next).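

At this aromatic carbon next to the ring nitrogen, a six-membered aromatic ring of carbon only, carrying fluorine, now stands alongside the five-membered furan-2-yl, and in this assay that exchange gives no change at the digits printed from compound 2 to compound 3 (within the scatter) at the largest response. Set against the 2-(azetidin-1-yl)pyridin-4-yl group, the same 3-fluorophenyl gives no change at the digits printed from compound 1 to compound 3 (within the scatter), so three aromatic groups of differing ring size and hetero atom content are not separated at this position on this read-out. Nothing at hand accounts for this absence of separation.

Going by these compounds, all three compounds carry an aromatic ring at this carbon, so how a non-aromatic group such as a simple amine, a carboxylic acid or a longer alkyl chain would read there remains open. Also open, on these data alone, is whether this flat picture holds once the carboxymethyl group on the neighbouring ring atom is changed.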